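From nitro to amino on compound 2

The source may report more compounds than this note shows. Statements on the series, on what has been measured and on what is new or still open speak of the compounds shown alone.

In a functional assay on MCF7 cells (Homo sapiens) for antiproliferative activity, read by MTT assay, with a stated time of 48 h (a lower number here means a stronger inhibitor, a higher number a weaker inhibitor), compound 2 `COc1cc(C(=O)/C=C/c2c[nH]c3ccccc23)cc([N+](=O)[O-])c1OC` gives 1290 nM. Compound 1 `COc1ccc2c(/C=C/C(=O)c3cc(OC)c(OC)c([N+](=O)[O-])c3)c[nH]c2c1` gives 662 nM, and compound 3 `COc1cc(C(=O)/C=C/c2cn(C)c3ccccc23)cc([N+](=O)[O-])c1OC` gives 1770 nM, so compound 2 stands within the scatter of both.

Compound 4 `COc1cc(C(=O)/C=C/c2c[nH]c3ccccc23)cc(N)c1OC` differs from compound 2 by one change, amino in place of nitro on an aromatic carbon.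

The two measured steps are small, a 1.9-fold higher number from compound 1 to compound 2 (0.29 log units; within the scatter) and a 1.4-fold higher number from compound 2 to compound 3 (0.14 log units; within the scatter), and neither touches the nitro group. No measurement therefore bears directly on this change, and the estimate starts from compound 2 at 1290 nM.

In this assay the estimated step is a 1.3-fold lower number from compound 2 to compound 4 (0.11 log units; within the scatter), so none beyond the scatter is expected, though with little confidence.

For compound 4 the expected value is 1000 nM, with an estimated range of 300 nM to 3500 nM.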

Compound 4, half-maximal inhibitory concentration: 595 nM
Compound 4: middle estimate off by 1.7-fold (0.23 log units), on the high side, and the stated range covers the measured number.
By their numbers in this assay, from the lowest: compounds 4, 1, 2 and 3 (each within the scatter of the next, the first and the last beyond it).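

Amino in place of nitro on this aromatic carbon, ortho to a methoxy group, gives the first step here that lies beyond the scatter: in this assay the change gives a 2.2-fold lower number from compound 2 to compound 4 (0.34 log units; beyond the scatter), though only modestly. The nitro group is therefore not required for activity at this position in compound 2, and amino, with fewer heavy atoms, does not cost activity. No measured evidence explains this step.

From the compounds shown here alone, whether other groups at this position, such as hydroxyl or acetamide, would match amino remains open. So does whether the same change would give a similar step from compound 1 or compound 3.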